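Heteroaryl exchange at the saturated ring carbon: compound 3

This account rests on a few compounds, and the source may have more. Where it says the series, first, only, none or still open, it means among the compounds named here.

Measured so far:
compound 1 `COc1ccccc1C1C(C#N)=C(N)N(c2cc(OC)c(OC)c(OC)c2)C2=C1C(=O)CC(C)(C)C2`: 70%
compound 2 `COc1cc(N2C(N)=C(C#N)C(c3cccs3)C3=C2CC(C)(C)CC3=O)cc(OC)c1OC`: 15%

In a functional assay on Ehrlich cells (Mus musculus) for cytotoxicity, tested at 50 ug/mL (a lower number here means a weaker effect, a higher number a stronger effect of the compound at the concentration tested), compound 1 gives 70% and compound 2 gives 15%. Among the compounds with values here, compound 2 stands lowest of the two numbers; the only step known runs a number 55 percentage points lower from compound 1 to compound 2 (beyond the scatter), so compound 2 is well separated from compound 1.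

Compound 3 `COc1cc(N2C(N)=C(C#N)C(c3ccc(C)o3)C3=C2CC(C)(C)CC3=O)cc(OC)c1OC` is not yet measured. It differs from compound 2 as follows: 5-methylfuran-2-yl in place of thiophen-2-yl on a saturated ring carbon.

Within the data shown here, no measured step covers this particular exchange. Among the measured compounds shown here, the single step known, a number 55 percentage points lower from compound 1 to compound 2 (beyond the scatter), concerns a different change and only shows that the group on this carbon can move the read-out a long way; it gives no direction for the present swap of one five-membered aromatic ring with one hetero atom for another. For compound 3 the expected step is therefore a number 5 percentage points higher from compound 2 to compound 3 (within the scatter), not beyond the scatter. Compound 3 is estimated at 20%, with a range from 5% to 45%.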

Compound 3, a percentage reported as activity, at one concentration (the size of the read-out at that concentration, not a potency): 41%
For compound 3 the middle estimate is 21 percentage points below the measured one; measured number inside the range.
By their numbers in this assay, from the lowest: compound 2; then compound 3; then compound 1.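

In this assay, the exchange of one five-membered aromatic ring with one hetero atom for another on this saturated ring carbon is not neutral (a number 26 percentage points higher from compound 2 to compound 3 (beyond the scatter)). The 5-methylfuran-2-yl group still falls short of the 2-methoxyphenyl group (a number 29 percentage points lower from compound 1 to compound 3 (beyond the scatter)), so the two five-membered rings differ clearly from each other and each stays under the six-membered aromatic group of compound 1. The available data offer nothing that accounts for these differences.

On these data alone, the exchange replaces sulfur with oxygen and adds a methyl group in one step, so the share of each in the higher read-out stays open. An unsubstituted furan-2-yl group and a 5-methylthiophen-2-yl group would separate the two, and whether any five-membered ring can match the 2-methoxyphenyl group also remains unanswered.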